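A Ring Nitrogen Enters: Expected Clearance for Compound 3

The compounds below may be only part of what the source reports. "The series", "measured", "known", "first", "only" and "open" are said of these compounds alone.

Compound 1 `COc1cc(C(=O)N2CCC(O)C(C)C2)cc2nc(NCc3cccc(Cl)c3)oc12`: 45 mL/min/kg
Compound 2 `COc1cc(C(=O)N2CC[C@H](O)[C@@H](C)C2)cc2nc(NCc3cccc(Cl)c3)oc12`: 36.7 mL/min/kg

Of the compounds shown here, two have been measured so far. In an ADME assay on cells (Hepatocyte, Rattus norvegicus, strain Wistar) for pharmacokinetics, read by LC-MS, with a stated time of 90 min, tested at 1 uM (on this read-out lower numbers stand for slow clearance and higher numbers for fast clearance), compound 1 gives 45 mL/min/kg, and compound 2 gives 36.7 mL/min/kg; the gap between them, a 1.2-fold lower number from compound 1 to compound 2 (0.09 log units; within the scatter), is within the scatter, so neither number can be said to stand apart from the other. The two compounds share all atoms and bonds, and what sets them apart is only (the fact that one of compounds 1 and 2 is drawn with a defined configuration and the other without, at the place where they differ).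

Compound 3 `COc1cc(C(=O)N2CCC(O)C(C)C2)cc2nc(NCc3cncc(Cl)c3)oc12` is not yet measured in this assay. It differs from compound 1 in one place: 5-chloropyridin-3-yl in place of 3-chlorophenyl on a saturated chain carbon bound to a nitrogen on an aromatic ring. Within the data shown here, no measured step touches this part of the molecule: the only step available concerns the saturated ring of the amide and the way its configuration is drawn, and it was itself within the scatter. There is therefore nothing in the numbers to point to a step in either direction for this change, and the expectation is a step of a 1.3-fold lower number from compound 1 to compound 3 (0.11 log units; within the scatter), with a wide allowance for the unknown. Compound 3 is estimated to give 35 mL/min/kg, with a range from 15 mL/min/kg to 75 mL/min/kg.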

Compound 3, clearance: 40 mL/min/kg
Beside the measured number, compound 3's estimate is 1.1-fold (0.06 log units) below it; low and high end bracket the measured number.
By their numbers in this assay, from the lowest: compounds 2, 3 and 1 (each within the scatter of the next).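

In this assay, the position on a saturated chain carbon bound to a nitrogen on an aromatic ring now has a measured step of its own: 5-chloropyridin-3-yl in place of 3-chlorophenyl gives a 1.1-fold lower number from compound 1 to compound 3 (0.05 log units; within the scatter). The earlier pair spoke only to the saturated ring of the amide and how its configuration is drawn, whereas this pair shows that a ring nitrogen, with the hydrogen-bond acceptor counted for 5-chloropyridin-3-yl, can enter this aromatic ring while the clearance number stays indistinguishable from that of compound 1, at least on this one pair. Nothing at hand explains this result or bears on the exchange of these two groups.

The compounds shown leave open whether 5-chloropyridin-3-yl would read the same way on the defined configuration drawn in compound 2, as this exchange is shown only on the amide drawn without a configuration. They also leave open whether a nitrile or a methoxy group in place of the chlorine, or a pyrimidine ring in place of the pyridine ring, would give a step beyond the scatter at this position.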